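Spirooxindole series: aryl swap on the triazole nitrogen

This account rests on a few compounds, and the source may have more. Where it says the series, first, only, none or still open, it means among the compounds named here.

Measured so far:
compound 1 `CC(=O)Nc1ccc(-n2nncc2CN2C(=O)C3(C(C#N)=C(N)Oc4c3c3nc5ccccc5nc3c3ccccc43)c3ccccc32)cc1` gives > 50000 nM in a functional assay on MCF7 cells (Homo sapiens) for antiproliferative activity, read by MTT assay, with a stated time of 48 h; on this read-out lower numbers stand for stronger inhibition and higher numbers for weaker inhibition; this is a limit of the assay, not a number.
compound 2 `Cc1cccc(-n2nncc2CN2C(=O)C3(C(C#N)=C(N)Oc4c(N)cc5nc6ccccc6nc5c43)c3ccccc32)c1` gives > 50000 nM in this assay; this too is a limit, not a number.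

Among the measured compounds shown here, compound 2 stands at the limit of the assay, as does the one other value shown, so nothing orders the two against each other and no size of step between them can be read off (the limit of > 50000 nM in this assay, at which 2 of the 2 values shown sit).

Compound 3 `N#CC1=C(N)Oc2c(N)cc3nc4ccccc4nc3c2C12C(=O)N(Cc1cnnn1-c1c(F)cccc1F)c1ccccc12` is the next member to be measured. It differs from compound 2 in one place: 2,6-difluorophenyl in place of 3-methylphenyl on an aromatic nitrogen.

For the measured compounds named here, no step between measured compounds is available, and both values shown sit at the limit. The expectation for this assay is therefore no step beyond the scatter from compound 2 to compound 3, most likely a further limit: the change a step that the limit leaves unreadable from compound 2 to compound 3 is the estimated one. Compound 3 is expected to give 60000 nM, with a range from 15000 nM to 250000 nM.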

Compound 3, half-maximal inhibitory concentration: > 50000 nM
Compound 3: only a limit was reported; the forecaster's own chance of this, stated with the estimate: 75%; the middle value is on the limit's open side.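

In this assay compound 3 gives > 50000 nM, again a limit and not a number. No step can be read between compound 2 and compound 3, as all values sit at the same limit: the limit of > 50000 nM in this assay, at which 3 of the 3 values shown sit.

The compounds shown leave open whether any group on the triazole nitrogen, or any change to the shared core, gives a readable value in this assay.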